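Methyl substitution on the fused core: growth inhibition notes

The compounds below may be only part of what the source reports. "The series", "measured", "known", "first", "only" and "open" are said of these compounds alone.

Of the compounds shown here, three have been measured in a functional assay on NCI-H460 cells (Homo sapiens); on this read-out lower numbers stand for stronger inhibition of growth and higher numbers for weaker inhibition of growth. Compound 1 `COc1ccc(-c2cc(O)c3cccnc3n2)cc1` gives 26300 nM in this assay. Compound 2 `Oc1cc(-c2ccc(Cl)cc2)nc2ncccc12` gives 38000 nM, and compound 3 `Cc1ccnc2nc(-c3ccc(Cl)cc3)cc(O)c12` gives 3720 nM.

The cores of compounds 1 and 2 differ by methoxy in place of chloro on an aromatic carbon. This gives a 1.4-fold higher number from compound 1 to compound 2 (0.16 log units; within the scatter), so the two values are not told apart. The change from compound 2 to compound 3 is methyl in place of hydrogen on an aromatic carbon. For the measured compounds named here, this gives a 10-fold lower number from compound 2 to compound 3 (1.01 log units; beyond the scatter), the only step in the set that clearly separates two compounds.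

Compound 4 `COc1ccc(-c2cc(O)c3ccc(C)nc3n2)cc1` has not been measured. It differs from compound 1 by methyl in place of hydrogen on an aromatic carbon. Going by the values given here, this is the same kind of change as the one from compound 2 to compound 3, but not the same: in compound 3 the methyl sits ortho to a fused ring, meta to a fused ring and opposite the ring nitrogen, whereas in compound 4 it sits next to the ring nitrogen, meta to a fused ring and para to a fused ring. Whether a methyl at this different place acts as it did in compound 3 is not shown by any measured pair.

The step that the estimate below means is expected to be a 2.9-fold lower number from compound 1 to compound 4 (0.47 log units; beyond the scatter), set smaller than the measured 10-fold lower number from compound 2 to compound 3 (1.01 log units; beyond the scatter) to allow for the differing surroundings of the place. Compound 4 is therefore expected to give about 9000 nM in this assay, estimated to lie between 3000 nM and 27000 nM.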

Compound 4, concentration for 50% growth inhibition: > 100000 nM
Compound 4: no number, only a limit; the forecaster's own chance of this, stated with the estimate: 5%; middle value at least 11-fold (1.04 log units) away from the limit.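

In this assay compound 4 gives > 100000 nM, which is a limit of the assay and not a number: the limit of > 100000 nM in this assay, at which 1 of the 4 values shown sits. Read against that limit, methyl in place of hydrogen on an aromatic carbon gives an at least 3.8-fold higher number from compound 1 to compound 4 (0.58 log units; beyond the scatter), so in this series the change does not carry over from one core to another with the same direction of effect: the same change on two cores in this assay, a 10-fold lower number (1.01 log units; beyond the scatter) from compound 2 to compound 3 and an at least 3.8-fold higher number (0.58 log units; beyond the scatter) from compound 1 to compound 4, at least 38-fold (1.58 log units) apart, beyond the scatter of two such steps. For the compounds shown here, this does not show what sets the two steps apart, since the methyl of compound 4 sits next to the ring nitrogen, at a different place from the methyl of compound 3, and compound 4 carries methoxy where compound 3 carries chloro; no measured pair separates these two differences, and the limit leaves the true size of the step open.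

The compounds shown leave open whether a methyl next to the ring nitrogen would act the same way with chloro in place of methoxy, and whether a methyl at the place it holds in compound 3 would keep its effect with methoxy present. Also open, from the compounds shown here alone, is how a group other than methyl, such as ethyl or an amine, would behave at either place.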